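Ortho-substituent swap on the benzamide in a quinoline series

A few compounds are considered here, and "the series" means these few. Any claim that something is new, unique, unknown or untested is made for them only; others in the source may bear on it.

Measured compounds:
- compound 1 `CCNc1cc(C)c2cc(NC(=O)c3ccc(Cl)c(Cl)c3)ccc2n1`: 28200 nM
- compound 2 `CCN1CCN(c2cc(C)c3cc(NC(=O)c4ccccc4C)ccc3n2)CC1`: 29200 nM
- compound 3 `Cc1cc(NCCN2CCN(C)CC2)nc2ccc(NC(=O)c3ccc(Cl)c(Cl)c3)cc12`: 2690 nM

In a functional assay on SK-BR-3 cells (Homo sapiens) for antiproliferative activity, read by MTT assay, with a stated time of 72 h (a higher number here means a weaker inhibitor, a lower number a stronger inhibitor), compound 2 gives the highest of the three numbers shown, but its value sits within the scatter of compound 1, so no order between those two can be claimed. For the measured compounds named here, compound 3 lies clearly apart from both; the one single-point step recorded, a 10-fold lower number from compound 1 to compound 3 (1.02 log units; beyond the scatter), concerns the side chain on the shared core and not the benzamide half.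

Compound 4 `CCN1CCN(c2cc(C)c3cc(NC(=O)c4ccccc4Cl)ccc3n2)CC1` differs from compound 2 only on the benzamide ring: chloro in place of methyl on an aromatic carbon. Going by the values given here, no measured pair in this set varies the group on that aromatic carbon, so the recorded step from compound 1 to compound 3 does not bear on this change. With nothing in the data pointing either way, the expectation for this assay is a step of no size beyond the scatter, a 1.1-fold lower number from compound 2 to compound 4 (0.05 log units; within the scatter). Compound 4 is therefore estimated at 26000 nM, with a range from 10000 nM to 65000 nM.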

Compound 4, half-maximal inhibitory concentration: > 50000 nM
Compound 4 gave a limit, no number; the forecaster's own chance of this, stated with the estimate: 10%; at least 1.9-fold (0.28 log units) between middle value and limit.
By their numbers in this assay, from the lowest: compound 3; then compounds 1 and 2 (each within the scatter of the next). At a limit, above all of these: compound 4.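

In this assay compound 4 gives a limit and not a number: > 50000 nM. Read as a step, an at least 1.7-fold higher number from compound 2 to compound 4 (0.23 log units; that floor lies within the scatter), so chloro in place of methyl on this aromatic carbon, ortho to a large group, cannot yet be told apart from no change, and the step has no upper end. This is still the first information on this position, and it offers no sign that chloro brings the number down relative to methyl; compound 4 stands alone at the limit: the limit of > 50000 nM in this assay, at which 1 of the 4 values shown sits.

On these data alone, the true size of the step remains open, as does the outcome of other groups on this aromatic carbon, such as an amine, a methoxy or a carboxylic acid. Also open, as far as these compounds go, is whether the gain seen in a 10-fold lower number from compound 1 to compound 3 (1.02 log units; beyond the scatter) would carry over to a benzamide with a 2-chlorophenyl group.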